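Compound 3 to compound 4: a step read from limits

The source may hold more compounds than are shown below. What is called first, only, known or untested is meant among the compounds shown, and "the series" means these compounds.

All values in an ADME assay on HepG2 cells (Homo sapiens) for cytotoxicity (a lower number here means that less compound is needed, a higher number that more compound is needed for the effect), so far are limits:
- compound 1 (`Cc1ccc(S(=O)(=O)N[C@@H](CC(=O)NC(C)(C)C)C(=O)NCCNC(=O)c2ccccc2)cc1`) gives > 11000 nM
- compound 2 (`Cc1ccc(S(=O)(=O)N[C@@H](CC(=O)NC(C)(C)C)C(=O)NCCNC(=O)Nc2ccccc2)cc1`) gives > 11000 nM
- compound 3 (`Cc1ccc(S(=O)(=O)N[C@@H](CC(=O)NC(C)(C)C)C(=O)NCCNC(=O)c2cccc(C(C)C)c2)cc1`) gives > 11000 nM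

Compound 3 gives a limit (> 11000 nM) and not a number. Compound 3 therefore has no rank within the series and stands with compounds 1 and 2 (the limit of > 11000 nM in this assay, at which 3 of the 3 values shown sit) .

Compound 4 (`Cc1ccc(S(=O)(=O)N[C@@H](CC(=O)NC(C)(C)C)C(=O)NCCNC(=O)c2c(O)cccc2F)cc1`) keeps the shared core and carries 2-fluoro-6-hydroxyphenyl in place of 3-isopropylphenyl on a carbonyl carbon .

Going by the values given here, three measured steps bear on this change: (a step that the two limits leave unreadable from compound 1 to compound 3) , (a step that the two limits leave unreadable from compound 2 to compound 3) and (a step that the two limits leave unreadable from compound 1 to compound 2) . None of them has a readable size, so no step beyond the scatter is expected in this assay, and no direction can be given. Compound 4 is expected to report a limit as well, on the sole ground of the shared position (the limit of > 11000 nM in this assay, at which 3 of the 3 values shown sit) .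

The expected step is small (a step that the limit leaves unreadable from compound 3 to compound 4) and remains a working assumption. The estimate for compound 4 is 15000 nM with an expected range from 6000 nM to 40000 nM as a working figure.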

Compound 4, half-maximal effective concentration: > 11000 nM
Compound 4: no number, only a limit (the forecaster's own chance of this, stated with the estimate: 85%); the middle value is on the limit's open side.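

In this assay compound 4 gives > 11000 nM, which is a limit. Going by these compounds alone, no step between compound 4 and compound 1, compound 2 or compound 3 can be read. The compounds shown leave open whether any change on this carbonyl carbon shifts the value at all: the limit of > 11000 nM in this assay, at which 4 of the 4 values shown sit.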